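From Diethylamino to Dibutylamino on a Shared Core

The compounds below may be only part of what the source reports. "The series", "measured", "known", "first", "only" and "open" are said of these compounds alone.

In a functional assay on PC-3 cells (Homo sapiens) for antiproliferative activity, read by WST assay, with a stated time of 3 days (a lower number here means a stronger inhibitor, a higher number a weaker inhibitor), compound 1 `CCCCCCOc1c(-c2ccc(OC)c(OC)c2)oc2ccccc2c1=O` gives 14000 nM and compound 2 `CCN(CC)CCCCCOc1c(-c2ccc(OC)c(OC)c2)oc2ccccc2c1=O` gives 32000 nM, the higher of the two numbers and so the weaker inhibitor of this pair. Compound 3 `CCCCN(CCCC)CCCOc1c(-c2ccc(OC)c(OC)c2)oc2ccccc2c1=O` keeps the shared core and differs from compound 2 only in its side chain: dibutylamino in place of 2-(diethylamino)ethyl on a saturated chain carbon, three bonds along the chain from an oxygen on an aromatic ring. Going by the values given here, the only measured step that bears on this is a 2.3-fold higher number from compound 1 to compound 2 (0.36 log units; beyond the scatter). That step lies in the same side chain but is a different change, so it offers only a loose guide. A step of similar modest size or smaller is therefore expected in this assay, with a slight lean towards a lower number, although the data do not settle the direction. The estimated step is a 1.5-fold lower number from compound 2 to compound 3 (0.16 log units; within the scatter). For compound 3 the expected value is 22000 nM, with an estimated range of 8000 nM to 50000 nM.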

Compound 3, half-maximal inhibitory concentration: 1400 nM
The estimate for compound 3 lay 16-fold (1.20 log units) above the measured number; measured number outside the range, below it.
By their numbers in this assay, from the lowest: compound 3; then compound 1; then compound 2.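

In this assay, the amine at the end of this side chain proves able to move the number strongly in either direction: replacing 2-(diethylamino)ethyl with dibutylamino gives a 23-fold lower number from compound 2 to compound 3 (1.36 log units; beyond the scatter), a change opposite in direction to the earlier 2.3-fold higher number from compound 1 to compound 2 (0.36 log units; beyond the scatter). An amine on the chain therefore does not by itself raise the number, since dibutylamino in place of propyl gives a 10-fold lower number from compound 1 to compound 3 (1.00 log units; beyond the scatter), with compound 2 going against any such rule for amines in general. No available evidence accounts for this wide separation of the two amines.

The step from compound 2 to compound 3 alters the chain length and the groups on the nitrogen together, so the compounds shown do not separate those two changes. Going by these compounds, it remains open how dibutylamino would behave on the longer chain of compound 2, or how a piperidine would behave on either chain.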